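The source may report more compounds than this note shows. Statements on the series, on what has been measured and on what is new or still open speak of the compounds shown alone.

Measured compounds:
Compound 1, `CN(C)c1nc2c(ncn2-c2ccccc2)c(=O)n1-c1ccccc1`. In a functional assay on OVCAR-3 cells (Homo sapiens) for cytotoxicity, read by MTT assay, with a stated time of 72 h (a higher number here means a weaker inhibitor, a lower number a stronger inhibitor), compound 1 gives > 100000 nM, which is a limit of the assay rather than a number.
Compound 2, `CCCCN(CCCC)c1nc2c(ncn2-c2ccccc2)c(=O)n1-c1ccccc1`. In this assay compound 2 gives 10000 nM.
Compound 3, `CCCCCN(CCCCC)c1nc2c(ncn2-c2ccccc2)c(=O)n1-c1ccc(Cl)cc1`. In this assay compound 3 gives > 100000 nM, again a limit of the assay and not a number.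

Compound 3 therefore sits at the limit of > 100000 nM in this assay, at which 2 of the 3 values shown sit, so its position among the numbers shown is known only as that limit. The only measured step among these compounds is an at least 10-fold lower number from compound 1 to compound 2 (1.00 log units; beyond the scatter), a lengthening of both chains on the amino nitrogen. Compound 4, `O=c1c2ncn(-c3ccccc3)c2nc(N2CCCCC2)n1-c1ccc(Cl)cc1`, differs from compound 3 by piperidin-1-yl in place of dipentylamino on an aromatic carbon. For the measured compounds named here, no measured step involves a ring in place of two open chains, and the one step recorded moves in the opposite sense, from shorter chains to longer ones. The step is therefore expected to be small, an at least 2.0-fold lower number from compound 3 to compound 4 (0.30 log units; that floor lies within the scatter), with a real chance that only a limit is reported. Compound 4 is estimated at 50000 nM, within a range of 10000 nM to 200000 nM.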

Compound 4, half-maximal inhibitory concentration: > 100000 nM
Compound 4 gave a limit, no number (the forecaster's own chance of this, stated with the estimate: 55%); at least 2.0-fold (0.30 log units) between middle value and limit.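

Compound 3 and compound 4 each give only a limit of the assay, not a number, so no step can be read between them: the limit of > 100000 nM in this assay, at which 3 of the 4 values shown sit. The compounds shown leave open how piperidin-1-yl and dipentylamino compare in this assay.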